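The compounds below may be only part of what the source reports. "The series", "measured", "known", "first", "only" and "open" are said of these compounds alone.

Compound 1 `CCOC(=O)CSc1nc2cc(-n3nc(C(C)(C)C)sc3=O)c(F)cc2s1` is the tightest binder of the three measured compounds: in an assay on isolated protein for inhibition of protoporphyrinogen oxidase (Homo sapiens), read by capillary electrophoresis (on this read-out lower numbers stand for stronger inhibition and higher numbers for weaker inhibition), compound 1 gives 340 nM. Compound 2 `CCOC(=O)CCSc1nc2cc(-n3nc(C(C)(C)C)sc3=O)c(F)cc2s1` differs from it by one change, ((ethoxycarbonyl)methyl in place of ethoxycarbonyl on a saturated chain carbon bound to a sulfur), and this change made a large step, a 27-fold higher number from compound 1 to compound 2 (1.44 log units; beyond the scatter), so that compound 2 gives 9260 nM. Compound 3 `CCOC(=O)CCSc1nc2cc(-n3nc(C(C)(C)C)sc3=O)c(Cl)cc2s1` carries chloro in place of fluoro; this made a modest step back, a 7.2-fold lower number from compound 2 to compound 3 (0.86 log units; beyond the scatter), and compound 3 gives 1280 nM. The difference between the core of compound 3 and that of compound 1 is not broken down here.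

Compound 4 `CCOC(=O)CCCSc1nc2cc(-n3nc(C(C)(C)C)sc3=O)c(Cl)cc2s1` has not yet been measured. It differs from compound 3 by (ethoxycarbonyl)methyl in place of ethoxycarbonyl on a saturated chain carbon, two bonds along the chain from a sulfur. Among the measured compounds shown here, this is the same kind of change as the one from compound 1 to compound 2, but not the same: there the place was on a saturated chain carbon bound to a sulfur, here it is on a saturated chain carbon, two bonds along the chain from a sulfur. Because the earlier step, a 27-fold higher number from compound 1 to compound 2 (1.44 log units; beyond the scatter), was large, a weakening step of similar direction is expected here too, estimated as a 9.4-fold higher number from compound 3 to compound 4 (0.97 log units; beyond the scatter). For compound 4 the expected value in this assay is 12000 nM, estimated to lie between 3000 nM and 50000 nM.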

Compound 4, inhibition constant: 17700 nM
Compound 4: middle estimate off by 1.5-fold (0.17 log units), on the low side, and the stated range covers the measured number.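

Swapping the 2-(ethoxycarbonyl)ethyl chain of compound 3 for the 3-(ethoxycarbonyl)propyl chain of compound 4 weakened binding, with a 14-fold higher number from compound 3 to compound 4 (1.14 log units; beyond the scatter) in this assay and a large step on this read-out. Set beside the earlier lengthening on the fluoro core, this step agrees with it in direction and, within the scatter, in size: the same change on two cores in this assay, a 27-fold higher number (1.44 log units; beyond the scatter) from compound 1 to compound 2 and a 14-fold higher number (1.14 log units; beyond the scatter) from compound 3 to compound 4, 2.0-fold (0.29 log units) apart, within the scatter of two such steps. So in these two pairs the same kind of change carried over from one core to the other, but two pairs show no general rule, they start from different chain lengths, and they give no reason for the loss of binding.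

Going by these compounds, it remains open whether a still longer chain would weaken binding further, and whether a carboxylic acid or an amide in place of the ethyl ester would behave like the esters. Also open, on these data alone, is how far chloro and fluoro differ when each carries the same (ethoxycarbonyl)methyl or 3-(ethoxycarbonyl)propyl chain.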